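Dropping the Chlorine from a Benzyl Group

This account rests on a few compounds, and the source may have more. Where it says the series, first, only, none or still open, it means among the compounds named here.

Of the compounds shown here, three built on a shared core have been measured in a functional assay (B cells) with Mus musculus as the target; a higher number here means that more compound is needed for the effect, a lower number that less compound is needed. Compound 1 `C=CCn1c(=O)n(CCC(CCOCc2ccccc2)CCOCc2ccccc2)c2nc(N)nc(O)c21` gives 7 uM. Compound 2 `Nc1nc(O)c2c(n1)n(C1OC(CO)[C@@H](O)[C@H]1O)c(=O)n2Cc1ccc(Cl)cc1` gives 14 uM, and compound 3 `C=CCn1c(=O)n([C@@H]2O[C@H](CO)[C@H]3OC(C)(CCC(=O)OCC)O[C@H]32)c2nc(N)nc(O)c21` gives 139 uM. Among these three numbers, compound 2 stands second highest. Its nearest neighbour is compound 1, whose number is lower but within the scatter, so the two cannot be told apart on this evidence. Compound 3 lies furthest away, with a higher number beyond the scatter.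

Compound 4 `Nc1nc(O)c2c(n1)n(C1OC(CO)[C@@H](O)[C@H]1O)c(=O)n2Cc1ccccc1` has not yet been measured. It differs from compound 2 in one place: hydrogen in place of chloro on an aromatic carbon. Among the measured compounds shown here, no pair of measured compounds that differ in a single place is available, so there is no measured step of this kind to lean on. Removing one chlorine from the aromatic ring is a small change, and the step is expected to be small, if anything toward a slightly higher number, and not beyond the scatter. The expected step of a 1.4-fold higher number from compound 2 to compound 4 (0.15 log units; within the scatter) reflects this. Compound 4 is therefore estimated at 20 uM, with a range from 8 uM to 50 uM.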

Compound 4, concentration for half-maximal effect: 6 uM
The estimate for compound 4 lay 3.3-fold (0.52 log units) above the measured number, and the stated range ends above it.
By their numbers in this assay, from the lowest: compounds 4, 1 and 2 (each within the scatter of the next, the first and the last beyond it); then compound 3.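

In this assay, among the compounds shown here, the change from 4-chlorobenzyl to benzyl gives a 2.3-fold lower number from compound 2 to compound 4 (0.37 log units; beyond the scatter) and is the first single-place step that can be read in this set. It shows that the chloro on this aromatic carbon is not needed for the effect, since less compound is needed once hydrogen replaces it. For the compounds shown here, the step is modest, but it runs toward a lower number and lies beyond the usual scatter, something the earlier compounds, which differ in more than one place, could not show. Nothing at hand explains why the number falls.

The compounds shown carry no other group on this aromatic carbon, such as fluoro, methyl, methoxy or an amine, so it stays open whether hydrogen is the best choice here. Also open, going by these compounds, is whether a chloro added to the benzyl groups of compound 1 would move the number the same way.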